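This account rests on a few compounds, and the source may have more. Where it says the series, first, only, none or still open, it means among the compounds named here.

For the measured compounds named here, compound 1 `N#CSc1cn([C@H]2C[C@H](O)[C@@H](CO)O2)c(=O)[nH]c1=O` is the weaker of the two compounds measured so far: in an ADME assay on L1210/0 cells (Mus musculus) for cytotoxicity, with a stated time of 48 h (a lower number here means a stronger inhibitor, a higher number a weaker inhibitor), compound 1 gives 78900 nM, the highest number of the pair. Compound 2 `CC(=O)OCCOCn1cnc2c(Cl)nc(I)nc21` gives 8600 nM in this assay, a gap beyond the scatter. Compound 3 `CC(C)(C)C#Cc1cn([C@H]2C[C@H](O)[C@@H](CO)O2)c(=O)[nH]c1=O` differs from compound 1 in one place: 3,3-dimethylbut-1-yn-1-yl in place of cyanosulfanyl on an aromatic carbon. Going by the values given here, no measured pair shows this change, so its effect is unknown. A modest step toward a lower number is expected, a 2.6-fold lower number from compound 1 to compound 3 (0.42 log units; beyond the scatter), but it could fall within the scatter. Compound 3 is expected to give 30000 nM in this assay, within 5000 nM to 150000 nM.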

Compound 3, half-maximal inhibitory concentration: > 200000 nM
Compound 3 ended at the assay's limit; the forecaster's own chance of this, stated with the estimate: 15%; middle value at least 6.6-fold (0.82 log units) away from the limit.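

In this assay, putting 3,3-dimethylbut-1-yn-1-yl in place of cyanosulfanyl on this aromatic carbon gives an at least 2.5-fold higher number from compound 1 to compound 3 (0.40 log units; beyond the scatter), so the number clearly depends on the group held here. Both groups contain a triple bond outside aromatic rings, so that feature alone does not keep the number at the level of compound 1. The step is only a minimum, because compound 3 stands at a limit: the limit of > 200000 nM in this assay, at which 1 of the 3 values shown sits. On these data alone, whether an amine, a carboxylic acid or a shorter chain on this carbon would give a lower number than compound 1 stays open.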